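Swapping Chloro for Acetamido: An Estimate for Compound 4

The source may hold more compounds than are shown below. What is called first, only, known or untested is meant among the compounds shown, and "the series" means these compounds.

Of the compounds shown here, three sharing one core have been tested in a functional assay on the whole organism with Rattus norvegicus as the target, at a dose of 1 mg/kg by the oral route; a higher number here means a stronger effect of the compound at the dose given, a lower number a weaker effect. Compound 1 `COc1cccc(-c2cc(Cl)cc(C(=O)Nc3nn[nH]n3)n2)c1` gives 51%, compound 2 `Nc1ccc(-c2cc(Cl)cc(C(=O)Nc3nn[nH]n3)n2)cc1` gives 100%, and compound 3 `COc1cc(C(=O)Nc2nn[nH]n2)nc(-c2ccc(Cl)cc2)c1` gives 0%, the lowest of the three, sitting beyond the scatter below both others. Compound 4 `COc1cc(C(=O)Nc2nn[nH]n2)nc(-c2ccc(NC(C)=O)cc2)c1` has not yet been measured. It differs from compound 3 in one place: acetamido in place of chloro on an aromatic carbon. Compound 2 shows the highest number, but it differs from compound 3 in two places, so no single step can be read from that pair. Compound 4 is expected to rise in this assay by a moderate step of a number 30 percentage points higher from compound 3 to compound 4 (beyond the scatter), large enough to clear the scatter. The estimate for compound 4 is 30%, with a range from 0% to 70%.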

Compound 4, a percentage reported as inhibition, in the whole organism at one dose (the size of the read-out at that dose, not a potency): 0%
The estimate for compound 4 lay 30 percentage points above the measured number; the measured number falls inside the stated range.
By their numbers in this assay, from the lowest: compounds 3 and 4 (each within the scatter of the next); then compound 1; then compound 2.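

In this assay, replacing chloro with acetamido on the aromatic carbon para to a large group gives no change at the digits printed from compound 3 to compound 4 (within the scatter). Within the data shown here, this is the first single-place step available at this position, and it shows that adding the acetamido group, with its hydrogen-bond donor and acceptor, produces no measurable gain at this dose. No available data explain this result.

On these data alone, whether a carboxylic acid or a longer amide chain at this position would produce a response remains open. So does whether acetamido would behave the same way on a different core.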